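This account rests on a few compounds, and the source may have more. Where it says the series, first, only, none or still open, it means among the compounds named here.

Series notes. Compound 1 `CN(C)Cc1cc2c(N)nc(-c3ccco3)nc2s1` gives 3550 nM in an assay on CHO-K1 cells for antagonist activity at adenosine receptor A1 (Homo sapiens), read by a beta-galactosidase reporter, with stated times of 15 min and 6 h; on this read-out lower numbers stand for stronger inhibition and higher numbers for weaker inhibition. Among the measured compounds shown here, compound 2 `Nc1nc(-c2ccco2)nc2sc(CN3CC=CCC3)cc12` gives 150 nM in this assay, the lower of the two numbers measured so far, and the only measured step, a 24-fold lower number from compound 1 to compound 2 (1.37 log units; beyond the scatter), concerns the group on the saturated chain carbon bound to an aromatic carbon. Compound 3 `Nc1nc(-c2ncco2)nc2sc(CN3CC=CCC3)cc12` is not yet measured; it keeps that part of compound 2 unchanged and differs only in 1,3-oxazol-2-yl in place of furan-2-yl on an aromatic carbon. For the measured compounds named here, no measured step touches the group on that aromatic carbon, so the step from compound 1 to compound 2 gives no guide to the size or direction of the change from compound 2 to compound 3. With nothing in the series pointing either way, the expected step for compound 3 is a 1.7-fold higher number from compound 2 to compound 3 (0.22 log units; within the scatter), none beyond the scatter, carrying a wide range. In this assay compound 3 is therefore estimated at 250 nM, between 70 nM and 900 nM.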

Compound 3, inhibition constant: 2960 nM
The estimate for compound 3 lay 12-fold (1.07 log units) below the measured number; the measured number lies above the stated range.
By their numbers in this assay, from the lowest: compound 2; then compounds 3 and 1 (each within the scatter of the next).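

In this assay, the group on the aromatic carbon between two ring nitrogen atoms has a strong bearing on the read-out: with the rest of compound 2 unchanged, 1,3-oxazol-2-yl in place of furan-2-yl gives a 20-fold higher number from compound 2 to compound 3 (1.30 log units; beyond the scatter). The two rings have the same count of heavy atoms and neither carries a net charge, so a large step here follows from exchanging one ring carbon for a nitrogen, which adds one counted hydrogen-bond acceptor. No available data bear on the reason for this step.

Open, from the compounds shown here alone, is whether other rings at this place, such as thiophen-2-yl or phenyl, keep a number as low as that of furan-2-yl. Also open, going by these compounds, is whether 1,3-oxazol-2-yl gives a step of similar size alongside the dimethylamino group of compound 1.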